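One Group Exchanged on Compound 3

The source may hold more compounds than are shown below. What is called first, only, known or untested is meant among the compounds shown, and "the series" means these compounds.

In a physicochemical assay for solubility, measured as kinetic solubility, with a stated time of 1 h, at pH 7.4 (a higher number here means a more soluble compound, a lower number a less soluble compound), compound 1 (`CS(=O)(=O)Nc1nc(-c2ccc(Cl)c(Cl)c2)cs1`) gives 429000 nM and compound 2 (`CC(=O)Nc1nc(-c2ccc(Cl)cc2)cs1`) gives 1000 nM. Compound 3 (`CC(=O)N[C@@H](C)C(=O)NC1=NN(c2ccc(Cl)c(Cl)c2)CC1`) gives 58000 nM, the second highest of the three numbers and beyond the usual scatter from each of the other two. Compound 4 (`O=C(NC1=NN(c2ccc(Cl)c(Cl)c2)CC1)c1ccncn1`) has pyrimidin-4-yl in place of 1-acetamidoethyl on a carbonyl carbon. Within the data shown here, no two measured compounds differ in only one place, so the data give no direct guide to this exchange, and any expectation stays rough. In this assay, a moderate fall beyond the scatter is expected, a 3.9-fold lower number from compound 3 to compound 4 (0.59 log units; beyond the scatter). For compound 4 the estimated value is 15000 nM, with an expected range of 3000 nM to 60000 nM.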

Compound 4, solubility: 13000 nM
Estimate against measurement, compound 4: 1.2-fold (0.06 log units) above, and the stated range covers the measured number.
By their numbers in this assay, from the lowest: compound 2; then compound 4; then compound 3; then compound 1.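

Among these compounds, this is the first reading of a single exchange at this position: in this assay putting pyrimidin-4-yl in place of 1-acetamidoethyl on the carbonyl carbon gives a 4.5-fold lower number from compound 3 to compound 4 (0.65 log units; beyond the scatter) on an otherwise unchanged structure. The exchange removes a hydrogen-bond donor and a defined stereocentre and brings in an aromatic ring, and this single step cannot separate these changes. Nothing measured here explains the fall. Going by these compounds, whether a phenyl ring, an amine or a longer chain on that carbonyl carbon would give a higher or lower number remains open.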